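The source may report more compounds than this note shows. Statements on the series, on what has been measured and on what is new or still open speak of the compounds shown alone.

Compound 1 `COc1cc(C)cc(-c2c(-c3ccnc(-c4ccc(C(C)=O)cc4)c3)cnn2CC#N)c1` gives 1950 nM in a functional assay on COLO 205 cells (Homo sapiens) for inhibition, read by sulforhodamine B assay, with a stated time of 48 h; on this read-out lower numbers stand for stronger inhibition of growth and higher numbers for weaker inhibition of growth. Its two companions are compound 2 `Cc1cc(O)cc(-c2nn(CC#N)cc2-c2ccnc(-c3ccc(Oc4ccccc4)cc3)c2)c1`, which gives 1800 nM, and compound 3 `Cc1cc(O)cc(-c2nn(CC#N)cc2-c2ccnc(-c3ccc(N(C)C)cc3)c2)c1`, which gives 1950 nM; all three values sit within the scatter of one another, so compound 1 stands level with the others. The step from compound 1 to compound 4 `COc1cc(C)cc(-c2c(-c3ccnc(-c4ccc(N(C)C)cc4)c3)cnn2CC#N)c1` consists of dimethylamino in place of acetyl on an aromatic carbon. Among the compounds with values here, no measured pair makes exactly this exchange, but the nearest comparison, a 1.1-fold higher number from compound 2 to compound 3 (0.03 log units; within the scatter), brings the same dimethylamino group in with no change beyond the scatter. On that basis the expected step is a 1.0-fold lower number from compound 1 to compound 4 (0.01 log units; within the scatter), that is, none beyond the scatter. Compound 4 is therefore estimated at 1900 nM, with a range from 900 nM to 4000 nM.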

Compound 4, concentration for 50% growth inhibition: 220 nM
For compound 4 the middle estimate is 8.6-fold (0.94 log units) above the measured one; the measured number lies below the stated range.
By their numbers in this assay, from the lowest: compound 4; then compounds 2, 1 and 3 (each within the scatter of the next).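

Within the data shown here, putting dimethylamino in place of acetyl on this aromatic carbon gives an 8.9-fold lower number from compound 1 to compound 4 (0.95 log units; beyond the scatter) in this assay, the only step here beyond the scatter. The same group replacing phenoxy gave just a 1.1-fold higher number from compound 2 to compound 3 (0.03 log units; within the scatter), so the outcome of bringing in dimethylamino here depends on what it replaces, on the rest of the molecule, or on both. No measurement available here accounts for the size of this step. Going by these compounds, it remains open whether a smaller amine such as methylamino, or a ring amine such as morpholine, would match dimethylamino at this carbon.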